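The source may report more compounds than this note shows. Statements on the series, on what has been measured and on what is new or still open speak of the compounds shown alone.

Among the three compounds measured in a functional assay on DU-145 cells (Homo sapiens) for antiproliferative activity, read by MTT assay, with a stated time of 72 h (on this read-out lower numbers stand for stronger inhibition and higher numbers for weaker inhibition), compound 3 `COc1cc2c(Nc3ccc(C#N)cc3)ncnc2cc1OCCCN1CCC(O)CC1` stands highest, at 74900 nM. Compound 1 `COc1cc2c(Nc3ccc(C#N)cc3)ncnc2cc1OCCCN1CCCC1` gives 14400 nM, and compound 2 `COc1cc2c(Nc3ccc(C#N)cc3)ncnc2cc1OCCCN1CCCCC1` gives 24400 nM. Compound 4 `COc1cc2c(Nc3ccc(C#N)cc3)ncnc2cc1OCCCN1CCC(c2ccccc2)CC1` differs from compound 3 by phenyl in place of hydroxy on a saturated ring carbon. The measured steps that bear on this change are a 3.1-fold higher number from compound 2 to compound 3 (0.49 log units; beyond the scatter) and a 5.2-fold higher number from compound 1 to compound 3 (0.72 log units; beyond the scatter), both beyond the scatter and both tied to the arrival of the hydroxy that now leaves. Its departure is expected to move the number back toward that of compound 2, while nothing measured shows what a phenyl on that carbon does. Compound 4 is therefore expected at 22000 nM, between 7000 nM and 70000 nM, a step of a 3.4-fold lower number from compound 3 to compound 4 (0.53 log units; beyond the scatter) in this assay.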

Compound 4, half-maximal inhibitory concentration: 6790 nM
For compound 4 the middle estimate is 3.2-fold (0.51 log units) above the measured one; measured number below the stated range.
By their numbers in this assay, from the lowest: compound 4; then compounds 1 and 2 (each within the scatter of the next); then compound 3.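

In this assay this ring carbon carries a large group without loss: the step from hydroxy to phenyl is large (an 11-fold lower number from compound 3 to compound 4 (1.04 log units; beyond the scatter)), and phenyl in place of hydrogen also lowers the number (a 3.6-fold lower number from compound 2 to compound 4 (0.56 log units; beyond the scatter)). The 4-phenylpiperidin-1-yl group likewise goes beyond pyrrolidin-1-yl (a 2.1-fold lower number from compound 1 to compound 4 (0.33 log units; beyond the scatter)), which gives compound 4 the lowest number of the four. Nothing at hand explains this gain. As far as these compounds go, whether it needs the aromatic ring stays open, since a cyclohexyl, benzyl or methyl on that carbon could be compared. From the compounds shown here alone, a methoxy-substituted phenyl or an amine there is equally open.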